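The source may report more compounds than this note shows. Statements on the series, on what has been measured and on what is new or still open speak of the compounds shown alone.

Series notes. Compound 1 `CCCCCCCC/C=C\CCCCCCCC[Se]C[C@H](N)C(=O)NCc1ccc(O)c(OC)c1` and compound 2 `CCCCCCCC/C=C\CCCCCCCC[Se]CCC(=O)NCc1ccc(O)c(OC)c1` share one core; compound 3 `CCCCCCCCCCCCCCCCOC(=O)CSC[C@H](N)C(=O)NCc1ccc(O)c(OC)c1` and compound 4 `CCCCCCCCCCCCCCCCOC(=O)CSCCC(=O)NCc1ccc(O)c(OC)c1` share another, and the difference between the two cores is not broken down here. In an assay on HEK293 cells for antagonist activity at transient receptor potential cation channel subfamily V member 2 (Rattus norvegicus), read by fluorescence and calcium flux, with a stated time of 5 min (a lower number here means a stronger inhibitor, a higher number a weaker inhibitor), compound 1 gives 1700 nM, compound 2 gives 1800 nM and compound 3 gives 1400 nM. All three of these numbers sit within the usual scatter of one another, so no ranking among them is drawn. The change hydrogen in place of amino on a saturated chain carbon bound to a carbonyl carbon and a saturated chain carbon produced a step of a 1.1-fold higher number from compound 1 to compound 2 (0.02 log units; within the scatter) in this assay. The same change, (hydrogen in place of amino on a saturated chain carbon bound to a carbonyl carbon and a saturated chain carbon), carries compound 3 to compound 4, and the place is worded identically in both pairs, so it is the same change. Compound 4 has not yet been measured in this assay. Because the earlier instance gave a 1.1-fold higher number from compound 1 to compound 2 (0.02 log units; within the scatter), a step of comparable size is expected here, a 1.1-fold higher number from compound 3 to compound 4 (0.06 log units; within the scatter), in this assay; a single precedent is the only support. Compound 4 is therefore estimated at 1600 nM in this assay, with a likely range from 800 nM to 3200 nM.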

Compound 4, half-maximal inhibitory concentration: > 10000 nM
Compound 4 gave a limit, no number (the forecaster's own chance of this, stated with the estimate: 5%); middle value at least 6.2-fold (0.79 log units) from the limit.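

In this assay compound 4 gives > 10000 nM, which is a limit of the assay and not a number. Hydrogen in place of amino on a saturated chain carbon bound to a carbonyl carbon and a saturated chain carbon gives an at least 7.1-fold higher number from compound 3 to compound 4 (0.85 log units; beyond the scatter), so the result of this change on one core does not transfer to the other in this pair of cores: the same change on two cores in this assay, a 1.1-fold higher number (0.02 log units; within the scatter) from compound 1 to compound 2 and an at least 7.1-fold higher number (0.85 log units; beyond the scatter) from compound 3 to compound 4, at least 6.7-fold (0.82 log units) apart, beyond the scatter of two such steps This rests on two pairs only, the second of which has an open upper end, and it does not show which difference between the two cores accounts for the gap or how large the step on the core of compound 3 really is.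

The compounds shown leave open whether a methylamino group or a hydroxyl at the same place would behave as amino does on the core of compound 3. They also leave open whether a carboxylic acid or an amide in place of the ester in the chain would alter the size of this step.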